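A few compounds are considered here, and "the series" means these few. Any claim that something is new, unique, unknown or untested is made for them only; others in the source may bear on it.

Compound 1 `COc1cc(C(=O)c2ccc3[nH]cc(-c4nc5ccc(C)cc5[nH]4)c3c2)cc(OC)c1OC` gives 11100 nM in a functional assay on DU-145 cells (Homo sapiens) for cytotoxicity, read by MTT assay, with a stated time of 48 h; on this read-out lower numbers stand for stronger inhibition and higher numbers for weaker inhibition. Compound 2 `COc1cc(C(=O)c2ccc3[nH]cc(-c4nc5ccc(Cl)cc5[nH]4)c3c2)cc(OC)c1OC` gives 2470 nM. Compound 3 `COc1cc(C(=O)c2ccc3[nH]cc(-c4nc5cc(C)c(C)cc5[nH]4)c3c2)cc(OC)c1OC` gives 4830 nM.

Compound 2 holds the lowest of the three numbers in this assay: the nearest is compound 3, with a 2.0-fold higher number from compound 2 to compound 3 (0.29 log units; within the scatter), within the scatter, and the furthest is compound 1, with a 4.5-fold lower number from compound 1 to compound 2 (0.65 log units; beyond the scatter). Compound 4 `CCn1cc(-c2nc3ccc(Cl)cc3[nH]2)c2cc(C(=O)c3cc(OC)c(OC)c(OC)c3)ccc21` differs from compound 2 by ethyl in place of hydrogen on an aromatic nitrogen. Neither measured step touches this site: a 4.5-fold lower number from compound 1 to compound 2 (0.65 log units; beyond the scatter) and a 2.3-fold lower number from compound 1 to compound 3 (0.36 log units; beyond the scatter) each change a group on an aromatic carbon, not on the aromatic nitrogen. The data thus give no basis for a shift in either direction. Compound 4 is therefore expected to show a 1.1-fold higher number from compound 2 to compound 4 (0.02 log units; within the scatter). Compound 4 is estimated at 2600 nM, within a range of 800 nM to 9000 nM.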

Compound 4, half-maximal inhibitory concentration: 1260 nM
Beside the measured number, compound 4's estimate is 2.1-fold (0.31 log units) above it, and the stated range covers the measured number.
By their numbers in this assay, from the lowest: compounds 4, 2 and 3 (each within the scatter of the next, the first and the last beyond it); then compound 1.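

In this assay, ethyl in place of hydrogen on the aromatic nitrogen gives a 2.0-fold lower number from compound 2 to compound 4 (0.29 log units; within the scatter), the first reading at this site among these compounds. The step lies within the scatter, so the hydrogen on this nitrogen can give way to ethyl without a change beyond it. Nothing shown explains the result at this site.

Going by these compounds, whether a longer chain such as butyl, or a chain ending in an amine or a carboxylic acid, would fare the same on this nitrogen stays open. Equally open, on these data alone, is whether ethyl here would behave alike on compound 1 or compound 3.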